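Aryl swap on the saturated ring carbon of compound 3

The source may hold more compounds than are shown below. What is called first, only, known or untested is meant among the compounds shown, and "the series" means these compounds.

Compound 1 `CC1=C(C(=O)OC2CCCCC2)C(c2cccc(Br)c2)C2=C(CC(C)(C)CC2=O)N1` gives 4150 nM in an assay on HEK293 cells for inhibition of neurogenic locus notch homolog protein 1 (Homo sapiens), read by a luciferase reporter and resazurin assay, with a stated time of 16 h; on this read-out lower numbers stand for stronger inhibition and higher numbers for weaker inhibition. Compound 2 `CC1=C(C(=O)OCC2CCN(C(=O)OC(C)(C)C)CC2)[C@H](c2cccc(Br)c2)C2=C(CC(C)(C)CC2=O)N1` gives 130 nM in this assay, and compound 3 `CC1=C(C(=O)OCC2CCN(C(=O)OC(C)(C)C)CC2)C(c2cccc(Br)c2)C2=C(CC(C)(C)CC2=O)N1` gives 360 nM in this assay. Compound 3 thus stands second highest of the three numbers: compound 2 lies nearest with a lower number, compound 1 lies furthest with a clearly higher number. Among the measured compounds shown here, the only single-point step measured so far is a 2.8-fold higher number from compound 2 to compound 3 (0.44 log units; beyond the scatter), which rests on the fact that one of compounds 2 and 3 is drawn with a defined configuration and the other without, at the place where they differ and involves no change of any substituent.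

Compound 4 `CC1=C(C(=O)OCC2CCN(C(=O)OC(C)(C)C)CC2)C(c2ccc3c(c2)OCCO3)C2=C(CC(C)(C)CC2=O)N1` differs from compound 3 by 2,3-dihydro-1,4-benzodioxin-6-yl in place of 3-bromophenyl on a saturated ring carbon. For the measured compounds named here, no measured step touches the aryl group on that saturated ring carbon, so the series gives no guide to direction or size for this change; the expectation can only be anchored on compound 3 with a wide range covering a modest move either way. Compound 4 is expected in this assay to give about 500 nM, within 150 nM to 2000 nM. The expected step is a 1.4-fold higher number from compound 3 to compound 4 (0.14 log units; within the scatter).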

Compound 4, half-maximal inhibitory concentration: 1520 nM
Compound 4: middle estimate off by 3.0-fold (0.48 log units), on the low side; the measured number falls inside the stated range.
By their numbers in this assay, from the lowest: compound 2; then compound 3; then compound 4; then compound 1.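

The aryl group on this saturated ring carbon is not a silent site in this assay: 2,3-dihydro-1,4-benzodioxin-6-yl in place of 3-bromophenyl gives a 4.2-fold higher number from compound 3 to compound 4 (0.63 log units; beyond the scatter) and lies beyond the usual scatter. Among the compounds shown here, this is the first measured evidence that the number responds to the aryl group itself, not only to how the stereocentre at this carbon is drawn, and of the two aryl groups tested here 3-bromophenyl gives the lower number. Nothing at hand accounts for this step.

On these data alone, it remains open whether a plain phenyl or a 3-chlorophenyl would stay close to compound 3 or move towards compound 4. For the compounds shown here, also open is whether the 2,3-dihydro-1,4-benzodioxin-6-yl compound would show a shift like the one seen for compound 2 if drawn with a defined configuration.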